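Shortening the hydroxyalkyl chain of the hydrazide analogue

The source may report more compounds than this note shows. Statements on the series, on what has been measured and on what is new or still open speak of the compounds shown alone.

Compound 1 `COc1cc(NC(C)CCCNC(=O)Nc2ccc(Cl)c(C(F)(F)F)c2)c2ncccc2c1`: 28000 nM
Compound 2 `COc1cc(NC(C)CCCNC(=O)NNC(=O)NCCCCCO)c2ncccc2c1`: > 100000 nM

In a functional assay on NCI-H460 cells (Homo sapiens) for inhibition, read by MTT assay, with a stated time of 4 days (a higher number here means a weaker inhibitor, a lower number a stronger inhibitor), compound 1 gives 28000 nM. For compound 2 this assay returns only a limit, > 100000 nM. For the measured compounds named here, the one measured step, an at least 3.5-fold higher number from compound 1 to compound 2 (0.55 log units; beyond the scatter), leaves compound 2 standing at the limit of > 100000 nM in this assay, at which 1 of the 2 values shown sits. Compound 3 `COc1cc(NC(C)CCCNC(=O)NNC(=O)NCCCO)c2ncccc2c1` differs from compound 2 by hydroxy in place of 2-hydroxyethyl on a saturated chain carbon, three bonds along the chain from an amide-type nitrogen. Going by the values given here, no measured step bears directly on this change; the only one available, an at least 3.5-fold higher number from compound 1 to compound 2 (0.55 log units; beyond the scatter), concerns the exchange that produced compound 2. A shorter chain of the same kind is therefore expected to leave this assay unchanged, the estimated step that the limit leaves unreadable from compound 2 to compound 3 being none beyond the scatter. Compound 3 is estimated at 150000 nM, within 60000 nM to 400000 nM.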

Compound 3, half-maximal inhibitory concentration: > 100000 nM
Compound 3 was reported as a limit (the forecaster's own chance of this, stated with the estimate: 70%); the middle value lies beyond the limit too.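

In this assay compound 3 gives > 100000 nM, which is a limit and not a number. Replacing 4-chloro-3-(trifluoromethyl)phenyl with ((3-hydroxypropyl)carbamoyl)amino gives an at least 3.5-fold higher number from compound 1 to compound 3 (0.55 log units; beyond the scatter), so the loss seen with the 5-hydroxypentyl chain also holds for the 3-hydroxypropyl chain. The step between compound 2 and compound 3 cannot be read, and neither chain gives a value inside the range of the read-out: the limit of > 100000 nM in this assay, at which 2 of the 3 values shown sit.

On these data alone, whether chain length matters at all in this assay stays open. Also open, as far as these compounds go, is whether an amine or a carboxylic acid in place of the terminal hydroxy would give a readable value.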